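From isopropyl to methyl on an aromatic nitrogen

The source may report more compounds than this note shows. Statements on the series, on what has been measured and on what is new or still open speak of the compounds shown alone.

Compound 1 (`Cn1c(/C=C2\SC(=O)N(CC(=O)Nc3cc(C(C)(C)C)on3)C2=O)nc2ccccc21`) gives 31400 nM
Compound 2 (`CC(C)n1c(/C=C2\SC(=O)N(CC(=O)N3CCCC3)C2=O)nc2ccccc21`) gives > 50000 nM as a limit

For the measured compounds named here, in a functional assay on DU-145 cells (Homo sapiens) for inhibition, read by MTT assay, with a stated time of 48 h (on this read-out higher numbers stand for weaker inhibition and lower numbers for stronger inhibition), compound 1 reads 31400 nM and is the only true number so far. Compound 2 stands at > 50000 nM in this assay as a limit and not a number. Compound 3 (`Cn1c(/C=C2\SC(=O)N(CC(=O)N3CCCC3)C2=O)nc2ccccc21`) carries methyl in place of isopropyl on an aromatic nitrogen next to the ring atom that bears a large group. Going by the values given here, no measured step shows what such a change does. A small step is expected in this assay with no firm direction and nothing clearly beyond the scatter. Among the compounds with values here, compound 1 at 31400 nM is the only guide to the level, so compound 3 is expected to remain weak. The estimated at least 1.1-fold lower number from compound 2 to compound 3 (0.04 log units; that floor lies within the scatter) is small. In this assay compound 3 is estimated at 45000 nM within a range of 18000 nM to 100000 nM as the expected reading.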

Compound 3, half-maximal inhibitory concentration: > 50000 nM
Compound 3 was reported as a limit; the forecaster's own chance of this, stated with the estimate: 55%; middle value at least 1.1-fold (0.04 log units) away from the limit.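

In this assay compound 3 gives > 50000 nM, a limit and not a number. Methyl on the aromatic nitrogen therefore does not bring the pyrrolidin-1-yl amide to a true reading, and the step from isopropyl to methyl cannot be read, because both compounds rest on: the limit of > 50000 nM in this assay, at which 2 of the 3 values shown sit.

With methyl held in place, pyrrolidin-1-yl in place of (5-(tert-butyl)-1,2-oxazol-3-yl)amino on a carbonyl carbon gives an at least 1.5-fold higher number from compound 1 to compound 3 (0.20 log units; that floor lies within the scatter), so this pair sets no firm order.

From the compounds shown here alone, it remains open whether a longer chain on the aromatic nitrogen, or a carboxylic acid in place of pyrrolidin-1-yl on the carbonyl carbon, would give a true number. Also open, going by these compounds, is how isopropyl on the aromatic nitrogen reads alongside the (5-(tert-butyl)-1,2-oxazol-3-yl)amino group, which would show the nitrogen change on a measurable background.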